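From dimethylamino to methoxy at the assay limit

The source may hold more compounds than are shown below. What is called first, only, known or untested is meant among the compounds shown, and "the series" means these compounds.

In an ADME assay on HEK293 cells (Homo sapiens) for cytotoxicity, with a stated time of 72 h (a lower number here means that less compound is needed, a higher number that more compound is needed for the effect), compound 1 (`Cc1cc(NC(=O)Nc2cccc([N+](=O)[O-])c2)c2ccccc2n1`) gives > 25000 nM, which is a limit of the assay. Compound 2 (`Cc1cc(NC(=O)Nc2cccc(N(C)C)c2)c2ccccc2n1`) gives > 25000 nM, also only a limit. Going by the values given here, the one measured step, a step that the two limits leave unreadable from compound 1 to compound 2, therefore has no readable size, and the evidence is the limit of > 25000 nM in this assay, at which 2 of the 2 values shown sit. Compound 3 (`COc1cccc(NC(=O)Nc2cc(C)nc3ccccc23)c1`) carries methoxy in place of dimethylamino on an aromatic carbon, methoxy in place of dimethylamino on an aromatic carbon. No step beyond the scatter is expected, and the estimated step is a number no higher from compound 2 to compound 3 (the limit leaves the size open). Compound 3 is expected at 25000 nM, with an estimated range of 10000 nM to 50000 nM.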

Compound 3, half-maximal effective concentration: > 25000 nM
Compound 3 ended at the assay's limit; the forecaster's own chance of this, stated with the estimate: 85%; the middle value lies on the limit itself.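

Going by these compounds alone, compound 3 gives > 25000 nM, again only a limit, so no step among compound 1, compound 2 and compound 3 can be read. The compounds shown leave open how far each lies past this limit, and whether nitro, dimethylamino and methoxy differ at all.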